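A few compounds are considered here, and "the series" means these few. Any claim that something is new, unique, unknown or untested is made for them only; others in the source may bear on it.

Measured so far:
- compound 1 `O=C(O)c1ccc(C(=O)/C(=C\c2ccc(Br)c([N+](=O)[O-])c2)SCc2ccc(Cl)cc2)cc1`: < 1000 ug/mL, a limit
- compound 2 `O=C(O)c1ccc(C(=O)/C(=C\c2ccc(Br)c([N+](=O)[O-])c2)SCc2ccc(F)cc2)cc1`: < 1000 ug/mL, a limit

In a physicochemical assay for solubility (on this read-out higher numbers stand for higher solubility and lower numbers for lower solubility), compound 1 stands only at a limit, < 1000 ug/mL, and no number is known for it. Among the measured compounds shown here, the series so far offers only (the limit of < 1000 ug/mL in this assay, at which 2 of the 2 values shown sit).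

Compound 3 `O=C(O)c1ccc(C(=O)/C(=C\c2ccc(F)c([N+](=O)[O-])c2)SCc2ccc(Cl)cc2)cc1` keeps the core of compound 1 and differs in one substituent: fluoro in place of bromo on an aromatic carbon. This is fluoro in place of bromo on an aromatic carbon, 4-bromo-3-nitrophenyl to 4-fluoro-3-nitrophenyl.

For the measured compounds named here, the only measured step is a step that the two limits leave unreadable from compound 1 to compound 2. It is fluoro in place of chloro at another place in the molecule, and it gives no size to carry over. No step beyond the scatter is expected in this assay, in either direction. The expected step is a step that the limit leaves unreadable from compound 1 to compound 3. Compound 3 is estimated at 300 ug/mL, with an expected range of 50 ug/mL to 1000 ug/mL.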

Compound 3, solubility: < 1000 ug/mL
Compound 3: a limit, no number (the forecaster's own chance of this, stated with the estimate: 85%); the middle value is on the limit's open side.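

Compound 1 and compound 3 both stand only at a limit in this assay, and no step can be read between them. Still open is the actual solubility of each compound shown, and whether fluoro in place of bromo shifts it at all: the limit of < 1000 ug/mL in this assay, at which 3 of the 3 values shown sit.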